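The compounds below may be only part of what the source reports. "The series", "measured", "known", "first", "only" and "open" are said of these compounds alone.

Measured so far in a functional assay on Jurkat cells (Homo sapiens); a higher number here means a weaker inhibitor, a lower number a stronger inhibitor:
Compound 1 `CC(C)[C@H](NC(=O)COc1cccc2ccccc12)C(=O)N[C@@H](CC(=O)O)C(=O)COc1cc(F)ccc1F`: compound 1 gives only a limit, > 100000 nM.
Compound 2 `CC(C)[C@H](NC(=O)COc1cccc2ccccc12)C(=O)N[C@@H](CC(=O)O)C(=O)COc1c(F)cccc1F`: compound 2 gives 2040 nM.
Compound 3 `CC(C)[C@H](NC(=O)COc1cccc2ccccc12)C(=O)N[C@@H](CC(=O)O)C(=O)COc1ccc(F)c(F)c1`: compound 3 gives only a limit, > 100000 nM.

Compound 3 thus stands at the limit of this assay, with no number of its own. Two of the three values sit there (the limit of > 100000 nM in this assay, at which 2 of the 3 values shown sit). Among the compounds with values here, the one readable step into compound 3 is an at least 49-fold higher number from compound 2 to compound 3 (1.69 log units; beyond the scatter); the step that the two limits leave unreadable from compound 1 to compound 3 cannot be read between the two limits. Compound 4 `CC(C)[C@H](NC(=O)COc1cccc2ccccc12)C(=O)N[C@@H](CC(=O)O)C(=O)COc1cccc(C(F)(F)F)c1F` differs from compound 3 in one place: 2-fluoro-3-(trifluoromethyl)phenyl in place of 3,4-difluorophenyl on an oxygen on a saturated carbon. Among the measured groups only 2,6-difluorophenyl in compound 2 has given a number; 2,5-difluorophenyl and 3,4-difluorophenyl both sit at the limit, and 2-fluoro-3-(trifluoromethyl)phenyl is untested. A return to a readable number is expected for compound 4, estimated at 20000 nM (range 2000 nM to 100000 nM). That estimate means an expected step of an at least 5.0-fold lower number from compound 3 to compound 4 (0.69 log units; beyond the scatter), with a further limit still a real possibility.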

Compound 4, half-maximal inhibitory concentration: 50400 nM
Beside the measured number, compound 4's estimate is 2.5-fold (0.40 log units) below it, and the stated range covers the measured number.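

Compound 4 is the second group at this position to give a number rather than a limit, so a readable value is not confined to 2,6-difluorophenyl. The gains over the two limit compounds are only floors, an at least 1.9-fold lower number from compound 3 to compound 4 (0.29 log units; that floor lies within the scatter) and an at least 1.9-fold lower number from compound 1 to compound 4 (0.29 log units; that floor lies within the scatter), and neither shows a real change by itself. Within the data shown here, the one fully readable comparison, a 25-fold higher number from compound 2 to compound 4 (1.39 log units; beyond the scatter), leaves 2,6-difluorophenyl ahead.

From the compounds shown here alone, how far compound 1 and compound 3 actually lie from compound 4 stays unknown. Also open, going by these compounds, is where pentafluorophenyl or unsubstituted phenyl would fall at this position.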